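Cytotoxicity Expected After Swapping an Ester for a Heteroaromatic

A few compounds are considered here, and "the series" means these few. Any claim that something is new, unique, unknown or untested is made for them only; others in the source may bear on it.

Measured so far:
compound 1, `COC(=O)c1ccc(NCc2cncn2Cc2ccc(C(C)(C)C)cc2)cc1-c1ccccc1`, result "not determined" (no result reported)
compound 2, `O=C(OC1CCCCC1)c1ccc(NCc2cncn2Cc2ccc(-c3ccccc3)cc2)cc1-c1ccccc1`, result > 10000 nM
compound 3, `CC(C)c1cccc(NCc2cncn2Cc2ccccc2)c1`, result > 1000 nM

These three results all come from a toxicity assay on NIH3T3 cells (Mus musculus) for cytotoxicity, read by resazurin assay; on this read-out higher numbers stand for an effect only at larger amounts of compound and lower numbers for an effect already at smaller amounts. For compound 2 the result is only a limit of the assay, > 10000 nM, not a number. Compound 3 likewise gave only a limit, > 1000 nM. Compound 1 has no result in this assay at all. Going by the values given here, compound 2 therefore stands at the limit of > 10000 nM in this assay, at which 1 of the 3 values shown sits, while the only other value sits at the limit of > 1000 nM in this assay, at which 1 of the 3 values shown sits; no single number is known for any compound, and no step between measured compounds can be given.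

Compound 4, `c1ccc(-c2ccc(Cn3cncc3CNc3ccc(-c4noc5ccccc45)c(-c4ccccc4)c3)cc2)cc1`, has not yet been measured in this assay. It differs from compound 2 by a group of 9 heavy atoms (7 carbon, 1 nitrogen, 1 oxygen; one five-membered aromatic ring with 2 hetero atoms, one six-membered aromatic ring of carbon only) in place of a group of 9 heavy atoms (7 carbon, 2 oxygen; one six-membered non-aromatic ring of carbon only), on an aromatic carbon. The leaving group is the cyclohexyloxycarbonyl; the entering group sits on an aromatic carbon of a six-membered aromatic ring of carbon only, ortho to a phenyl group and para to a large group.

With both measured neighbours at limits, a step in this assay beyond the scatter is not expected in either direction. Compound 4 is therefore estimated at 10000 nM, within 3000 nM to 30000 nM, and the expected change is a number no higher from compound 2 to compound 4 (the limit leaves the size open), most likely reported again only as a limit.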

Compound 4, half-maximal effective concentration: > 10000 nM
Compound 4: no number, only a limit; the forecaster's own chance of this, stated with the estimate: 70%; the middle value sits exactly at the limit.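

In this assay compound 4 gives only a limit, > 10000 nM, and not a number. Compound 2 also stands only at a limit, so no step can be read between compound 2 and compound 4. The compounds shown leave open whether replacing the cyclohexyloxycarbonyl with the entering group changes cytotoxicity at all, and at what concentration either compound would show an effect.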